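A thiophen-2-yl for furan-3-yl swap on a shared core

This account rests on a few compounds, and the source may have more. Where it says the series, first, only, none or still open, it means among the compounds named here.

Among the measured compounds shown here, three related compounds have been measured so far in an ADME assay on MRC5 cells (Homo sapiens), read by MTT assay, with a stated time of 72 h (on this read-out lower numbers stand for stronger inhibition and higher numbers for weaker inhibition), and only one gave a true number. For the measured compounds named here, compound 3 `Cc1ncnc2c1c(-c1ccoc1)cn2[C@@H]1O[C@H](CO)[C@@H](O)[C@H]1O` gives 98300 nM in this assay and this is the single number available. Compound 1 `CSc1ncnc2c1c(-c1cccs1)cn2[C@@H]1O[C@H](CO)[C@@H](O)[C@H]1O` reads > 100000 nM in this assay and this is a limit of the assay, not a number. Compound 2 `CNc1ncnc2c1c(-c1cccs1)cn2[C@@H]1O[C@H](CO)[C@@H](O)[C@H]1O` reads > 100000 nM in this assay and this too is a limit. The series is thus marked by the limit of > 100000 nM in this assay, at which 2 of the 3 values shown sit, with one number beside it.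

Compound 4 `Cc1ncnc2c1c(-c1cccs1)cn2[C@@H]1O[C@H](CO)[C@@H](O)[C@H]1O` differs from compound 3 in one place, thiophen-2-yl in place of furan-3-yl on an aromatic carbon, and thiophen-2-yl in place of furan-3-yl on an aromatic carbon sets out that change. Going by the values given here, the only measured step is a step that the two limits leave unreadable from compound 1 to compound 2 and it concerns a different group, so it offers no size to carry over. Among the compounds with values here, no measured step tests this swap, so no change beyond the usual scatter is expected in this assay and no clear direction is claimed. The estimate starts from compound 3 at 98300 nM and stays close to it. The expected step is a 1.2-fold lower number from compound 3 to compound 4 (0.06 log units; within the scatter) and it is small. Compound 4 is estimated at 85000 nM with an expected range from 30000 nM to 100000 nM in this assay for now.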

Compound 4, half-maximal inhibitory concentration: > 100000 nM
Compound 4: no number, only a limit; the forecaster's own chance of this, stated with the estimate: 50%; middle value at least 1.1-fold (0.07 log units) away from the limit.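

In this assay, among the compounds shown here, putting thiophen-2-yl in place of furan-3-yl on this aromatic carbon gives an at least 1.0-fold higher number from compound 3 to compound 4 (0.00 log units; that floor lies within the scatter), and this is the first measured test of the swap on the shared core. The result for compound 4 is a limit and not a number, so this step has a floor but no measured size, and that floor does not separate the two compounds beyond the usual scatter. The steps to compound 4 from compound 1 and from compound 2 cannot be read, and the series now gathers at a single limit: the limit of > 100000 nM in this assay, at which 3 of the 4 values shown sit.

Going by these compounds, it remains open whether a different group on this aromatic carbon, such as a phenyl ring or an aminomethyl group, would give a true number well under that limit. Also open, on these data alone, is whether furan-3-yl paired with methylamino or methylsulfanyl, in place of the methyl group of compound 3, would give a true number, which could show whether the swap reads the same on those versions of the core.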